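This account rests on a few compounds, and the source may have more. Where it says the series, first, only, none or still open, it means among the compounds named here.

Compound 3 `Cc1c(CC(O)COCc2ccccc2)n(COCC[Si](C)(C)C)c(=O)[nH]c1=O` stands at the edge of what a functional assay on HeLa cells (Homo sapiens) for antiproliferative activity, read by MTT assay, with a stated time of 72 h (a higher number here means a weaker inhibitor, a lower number a stronger inhibitor), can report. In this assay compound 3 gives > 100000 nM, which is a limit and not a number. Compound 2 `Cc1c(CC(O)COCc2ccccc2)[nH]c(=O)[nH]c1=O` likewise gives > 100000 nM, again a limit. The step that the two limits leave unreadable from compound 2 to compound 3 therefore stays unreadable, as the limit of > 100000 nM in this assay, at which 2 of the 3 values shown sit, shows. Compound 1 `COCn1c(CC(COCc2ccccc2)COCc2ccccc2)c(C)c(=O)[nH]c1=O` is the only one of the three with a number, giving 29700 nM in this assay. Compound 4 `COCn1c(CC(O)COCc2ccccc2)c(C)c(=O)[nH]c1=O` differs from compound 3 in that (a hydrogen atom in place of a group of 5 heavy atoms (4 carbon, 1 silicon; no ring), on a saturated chain carbon bound to an oxygen on a saturated carbon). Among the measured compounds shown here, no measured step covers this change, and the one measured step has no readable size. Compound 4 is expected to remain weak, the step from compound 3 estimated as an at least 1.2-fold lower number from compound 3 to compound 4 (0.09 log units; that floor lies within the scatter). Compound 4 is estimated at 80000 nM, between 25000 nM and 300000 nM.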

Compound 4, half-maximal inhibitory concentration: > 100000 nM
Compound 4: a limit, no number (the forecaster's own chance of this, stated with the estimate: 50%); at least 1.2-fold (0.09 log units) between middle value and limit.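

In this assay, among the compounds shown here, the change of (benzyloxy)methyl to hydroxy on a saturated chain carbon bound to two saturated chain carbons gives the first readable step at this position: an at least 3.3-fold higher number from compound 1 to compound 4 (0.52 log units; beyond the scatter). With hydroxy there, compound 2, compound 3 and compound 4 all stay at a limit, whichever group stands on the aromatic nitrogen. The steps among these three cannot be read: the limit of > 100000 nM in this assay, at which 3 of the 4 values shown sit.

From the compounds shown here alone, how far above that limit the hydroxy compounds lie remains open. So does whether an amine or a carboxylic acid in place of the hydroxy would give a readable value.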